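Swapping the Benzyl Substituent in a Bombesin Receptor-3 Agonist Series

A few compounds are considered here, and "the series" means these few. Any claim that something is new, unique, unknown or untested is made for them only; others in the source may bear on it.

Of the compounds shown here, two sharing one core have been measured in an in vitro functional assay on cells for agonist activity at Bombesin receptor subtype-3 (Homo sapiens), read by luminescence and calcium flux; a higher number here means that more compound is needed for the effect, a lower number that less compound is needed. Compound 1 `COc1cccc(Cc2cnc(CCc3ccc(-c4ccccc4C(=O)O)cc3)[nH]2)c1` carries a 3-methoxyphenyl group on a saturated chain carbon bound to an aromatic carbon, and in this assay compound 1 gives 4120 nM. Compound 2 `O=C(O)c1ccccc1-c1ccc(CCc2ncc(Cc3ccc(Cl)cc3)[nH]2)cc1` carries a 4-chlorophenyl group at that place, and in this assay compound 2 gives 2290 nM. Among the measured compounds shown here, only one comparison exists: a 1.8-fold lower number from compound 1 to compound 2 (0.26 log units; within the scatter). For the measured compounds named here, compound 2 therefore stands beside compound 1, its only neighbour, at a distance that the measurement cannot resolve.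

Compound 3 `O=C(O)c1ccccc1-c1ccc(CCc2ncc(Cc3cccc(F)c3)[nH]2)cc1` has not yet been measured. It differs from compound 2 in one place: 3-fluorophenyl in place of 4-chlorophenyl on a saturated chain carbon bound to an aromatic carbon. Going by the values given here, the single step that bears on this change is the one between compound 1 and compound 2, where exchanging the group at the same place moved the number by less than the scatter. A change of similar size is therefore expected here, with no clear direction. The expected step is a 1.3-fold higher number from compound 2 to compound 3 (0.12 log units; within the scatter). Compound 3 is expected to give 3000 nM in this assay, with a range from 1200 nM to 8000 nM.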

Compound 3, half-maximal effective concentration: 159 nM
Compound 3: middle estimate off by 19-fold (1.28 log units), on the high side; the whole stated range lies above it.
By their numbers in this assay, from the lowest: compound 3; then compounds 2 and 1 (each within the scatter of the next).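

In this assay, the group on this saturated chain carbon matters far more than the first pair suggested: 3-fluorophenyl in place of 4-chlorophenyl gives a 14-fold lower number from compound 2 to compound 3 (1.16 log units; beyond the scatter), while the earlier exchange gave only a 1.8-fold lower number from compound 1 to compound 2 (0.26 log units; within the scatter). Fluoro in place of methoxy on an aromatic carbon, which turns 3-methoxyphenyl into 3-fluorophenyl, gives a 26-fold lower number from compound 1 to compound 3 (1.41 log units; beyond the scatter), so the identity of the small group on the ring can by itself produce a large step, and compound 1 shows that a group at the 3 of the name does not guarantee a low number. Nothing available here explains the size of these steps.

The change from 4-chlorophenyl to 3-fluorophenyl alters both the halogen and its numbered place at once, so the compounds shown leave open which of the two goes with the lower number; 3-chlorophenyl and 4-fluorophenyl at this place would separate them. Also open, as far as these compounds go, is how far the trend reaches, for example whether plain phenyl or 3,5-difluorophenyl would read closer to compound 3 or to compound 2.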